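The compounds below may be only part of what the source reports. "The series", "measured", "known", "first", "only" and "open" are said of these compounds alone.

Compound 1 `CCOC(=O)C1=C(N)Oc2ccccc2C1C(C#N)C(=O)OCC` gives 94000 nM in a functional assay on Jurkat cells for inhibition of Apoptosis regulator Bcl-2 (Homo sapiens); a lower number here means a stronger inhibitor of growth, a higher number a weaker inhibitor of growth.
Compound 2 `CCOC(=O)C1=C(N)Oc2ccc(CC)cc2C1C(C#N)C(=O)OCC` gives 12000 nM in this assay.

Among the measured compounds shown here, of the two numbers known so far, compound 1 stands highest, meaning it is the weaker inhibitor of growth of the pair; its only neighbour is compound 2, reached by a step that is modest but clearly beyond the scatter a 7.8-fold lower number from compound 1 to compound 2 (0.89 log units; beyond the scatter).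

Compound 3 `CCOC(=O)C1=C(N)Oc2ccc(-c3ccccc3)cc2C1C(C#N)C(=O)OCC` has not yet been measured. It differs from compound 1 in a single place: phenyl in place of hydrogen on an aromatic carbon. For the measured compounds named here, the one measured step that bears on this change is the one in which ethyl replaced hydrogen on an aromatic carbon of the same shared core, which gave a 7.8-fold lower number from compound 1 to compound 2 (0.89 log units; beyond the scatter). Going by the values given here, only this single step is available, so the footing is thin. Since phenyl, like ethyl, is a carbon-only group entering where a hydrogen stood, a step of about the same size and in the same direction, toward a lower number, is expected a 10-fold lower number from compound 1 to compound 3 (1.02 log units; beyond the scatter). Compound 3 is therefore estimated to give roughly 9000 nM, with the range running from 2500 nM to 40000 nM.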

Compound 3, concentration for 50% growth inhibition: 4200 nM
Estimate against measurement, compound 3: 2.1-fold (0.33 log units) above, and the stated range covers the measured number.
By their numbers in this assay, from the lowest: compound 3; then compound 2; then compound 1.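

In this assay, the aromatic carbon that carried ethyl in compound 2 now has a second carbon-only group that lowers the number, and phenyl goes further than ethyl did (a 22-fold lower number from compound 1 to compound 3 (1.35 log units; beyond the scatter)). The comparison between the two groups is also beyond the scatter (a 2.9-fold lower number from compound 2 to compound 3 (0.46 log units; beyond the scatter)), so at this place the identity of the incoming group matters, not merely the loss of hydrogen. Nothing supplied here accounts for the gap between the aromatic ring and the ethyl chain, so the result remains an observation without a known cause.

These three compounds cannot show whether the trend depends on carbon-only groups, since none of them places an amine, a carboxylic acid or a methoxy group on this aromatic carbon. They also leave open whether a longer chain such as butyl would match phenyl, whether a substituted phenyl ring or a pyridine ring would lower the number further, and whether phenyl would give a similar step on another aromatic carbon of the shared core.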